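This account rests on a few compounds, and the source may have more. Where it says the series, first, only, none or still open, it means among the compounds named here.

The measured compounds:
compound 1 `O=C(O)c1csc(-n2nc(-c3ccccc3)c3ccc(F)cc32)n1` with 2 nM
compound 2 `Nc1ccc2c(-c3ccccc3)nn(-c3nc(C(=O)O)cs3)c2c1` with 19 nM
compound 3 `O=C(O)c1csc(-n2nc(-c3cccc(F)c3)c3ccccc32)n1` with 20 nM

All three were tested in an assay on isolated protein for antagonist activity at prostaglandin E2 receptor EP1 subtype (Homo sapiens), read by reporter gene assay; on this read-out lower numbers stand for stronger inhibition and higher numbers for weaker inhibition. Compound 3 gives the highest of the three numbers, but its value and that of compound 2 lie within the scatter of each other, so no order between those two can be read. Compound 1 gives a clearly lower number than compound 3. Going by the values given here, the only step between two compounds that differ in one place is a 9.5-fold higher number from compound 1 to compound 2 (0.98 log units; beyond the scatter).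

Compound 4 `O=C(O)c1csc(-n2nc(N3CCCCC3)c3ccccc32)n1` has not yet been measured. It arises from compound 3 by piperidin-1-yl in place of 3-fluorophenyl on an aromatic carbon. Among the compounds with values here, none of the measured steps touches this place: the step from fluoro to amino concerns another part of the shared core, and compound 1 and compound 3 differ in where the fluoro sits, for which no single-place step is given. Swapping an aromatic ring for a non-aromatic ring with one hetero atom is a larger change than any measured here, so the expectation rests on little. Compound 4 is expected to give a higher number, by about a 5.0-fold higher number from compound 3 to compound 4 (0.70 log units; beyond the scatter). Compound 4 is estimated at 100 nM, in a range from 20 nM to 600 nM.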

Compound 4, half-maximal inhibitory concentration: 16 nM
For compound 4 the middle estimate is 6.3-fold (0.80 log units) above the measured one; the whole stated range lies above it.
By their numbers in this assay, from the lowest: compound 1; then compounds 4, 2 and 3 (each within the scatter of the next).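

In this assay, putting piperidin-1-yl in place of 3-fluorophenyl, on the aromatic carbon next to the ring nitrogen, gives a 1.3-fold lower number from compound 3 to compound 4 (0.10 log units; within the scatter) and so shows no difference that can be read between the two groups. Going by these compounds alone, this is the first single-place information about this position, since the only earlier step concerned another part of the shared core, and it shows that a six-membered aromatic ring of carbon only and a six-membered non-aromatic ring with 1 hetero atom can stand here without a step beyond the scatter. Nothing measured here bears on why the two groups read alike.

The compounds shown leave open how far this holds for other groups on the same carbon, such as morpholin-4-yl, a smaller ring such as pyrrolidin-1-yl, an open-chain dimethylamino group or a plain methyl. They also leave open whether piperidin-1-yl at this place would give a similar number when combined with the fluoro on the shared core of compound 1, or with the amino on that of compound 2.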